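From compound 2 to compound 3: a stability estimate

This account rests on a few compounds, and the source may have more. Where it says the series, first, only, none or still open, it means among the compounds named here.

Compound 1 `Nc1nc(NCCNc2ncc(-c3ncc[nH]3)c(-c3ccc(F)cc3Cl)n2)ccc1[N+](=O)[O-]` and compound 2 `Nc1nc(NCCNc2ncc(-c3ncc[nH]3)c(-c3cc(F)c(Cl)cc3F)n2)ccc1[N+](=O)[O-]` share one core and differ only in the aryl group attached to it. In an ADME assay on microsomes from liver (Canis lupus familiaris) for metabolic stability (on this read-out higher numbers stand for a longer-lived compound and lower numbers for a shorter-lived compound), compound 1 gives > 0.5 h, which is a limit of the assay rather than a number. In this assay compound 2 gives > 0.5 h, again a limit and not a number. Going by the values given here, the two results sit together at the limit of > 0.5 h in this assay, at which 2 of the 2 values shown sit, so the only measured step, a step that the two limits leave unreadable from compound 1 to compound 2, cannot be read in either direction or size. Compound 2 therefore stands at the upper edge of what the measurement reports, with no number beyond that edge.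

Compound 3 `COc1cc(Cl)ccc1-c1nc(NCCNc2ccc([N+](=O)[O-])c(N)n2)ncc1-c1ncc[nH]1` differs from compound 2 by 4-chloro-2-methoxyphenyl in place of 4-chloro-2,5-difluorophenyl on an aromatic carbon. No measured step bears on this change, because the one step shown, a step that the two limits leave unreadable from compound 1 to compound 2, is unreadable. Compound 3 is therefore expected to sit near the same limit, estimated at 0.6 h, within a range from 0.3 h to 1.5 h. The expected step that the limit leaves unreadable from compound 2 to compound 3 is estimated to stay within the usual scatter.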

Compound 3, half-life: > 0.5 h
Compound 3: a limit, no number (the forecaster's own chance of this, stated with the estimate: 65%); the middle value is on the limit's open side.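

Compound 3 gives only a limit in this assay, not a number, as do compound 1 and compound 2, so none of the steps among these three compounds can be read: the limit of > 0.5 h in this assay, at which 3 of the 3 values shown sit.

The compounds shown leave open how long each one actually lasts, and whether changing the aryl group alters that at all.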